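Working notes: from compound 1 to compound 3

The source may report more compounds than this note shows. Statements on the series, on what has been measured and on what is new or still open speak of the compounds shown alone.

Measured so far:
compound 1, `CC#CCn1c(N2CCC[C@@H](N)C2)nc2c1c(=O)n(CCCN1CCN(c3ncc(C)cn3)CC1)c(=O)n2C`, 2560 nM
compound 2, `CC#CCn1c(N2CCC[C@@H](N)C2)nc2c1c(=O)n(CCCN1CCC(c3nc(-c4ccccc4)c[nH]3)CC1)c(=O)n2C`, 600 nM

In a functional assay on HEK293 cells for agonist activity at Glucose-dependent insulinotropic receptor (Homo sapiens), read by a luciferase reporter (on this read-out higher numbers stand for an effect only at larger amounts of compound and lower numbers for an effect already at smaller amounts), compound 1 gives 2560 nM, the highest of the two numbers. Compound 2 gives 600 nM, a lower number, and the gap between the two lies beyond the scatter.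

Compound 3, `CC#CCn1c(N2CCC[C@@H](N)C2)nc2c1c(=O)n(CCCN1CCN(c3ncc(CC)cn3)CC1)c(=O)n2C`, differs from compound 1 by methyl in place of hydrogen on a saturated chain carbon bound to an aromatic carbon, so methyl becomes ethyl and 5-methylpyrimidin-2-yl becomes 5-ethylpyrimidin-2-yl. Within the data shown here, no measured pair shows a change of this kind. The step from compound 1 to compound 3, a 1.2-fold lower number from compound 1 to compound 3 (0.09 log units; within the scatter), is expected to stay within the scatter, with no clear direction. Compound 3 is therefore estimated at 2100 nM, with a range from 700 nM to 6500 nM.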

Compound 3, half-maximal effective concentration: 3990 nM
Estimate against measurement, compound 3: 1.9-fold (0.28 log units) below; low and high end bracket the measured number.
By their numbers in this assay, from the lowest: compound 2; then compounds 1 and 3 (each within the scatter of the next).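

Methyl in place of hydrogen on a saturated chain carbon bound to an aromatic carbon, turning 5-methylpyrimidin-2-yl into 5-ethylpyrimidin-2-yl, gives the first one-place comparison in the series. In this assay this is a 1.6-fold higher number from compound 1 to compound 3 (0.19 log units; within the scatter), so the added methyl does not separate compound 3 from compound 1. No measured evidence bears on this result.

From the compounds shown here alone, whether a longer chain such as propyl, or an amine or a carboxylic acid, at this place would move the number beyond the scatter remains open.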